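A Cytotoxicity Limit Carried from Compound 3 to Compound 4

The source may hold more compounds than are shown below. What is called first, only, known or untested is meant among the compounds shown, and "the series" means these compounds.

Compound 1 `CS(=O)(=O)CCn1c(Cn2cc(S(C)(=O)=O)c3ccccc32)nc2ccccc21`: > 100000 nM
Compound 2 `CNS(=O)(=O)c1cn(Cc2nc3cc(Cl)ccc3n2CCCS(C)(=O)=O)c2ccccc12`: > 100000 nM
Compound 3 `CC(C)(CO)Cn1c(Cn2nc(S(C)(=O)=O)c3ccncc32)nc2cc(Cl)ccc21`: > 100000 nM

In an ADME assay on HEp-2 cells (Homo sapiens) for cytotoxicity, with a stated time of 4 days (a lower number here means that less compound is tolerated, a higher number that more compound is tolerated), compound 1 returns > 100000 nM, which is a limit of the assay and not a number. Compound 2 likewise returns > 100000 nM, again a limit. Compound 3 returns > 100000 nM, also a limit. Compound 3 therefore stands exactly where the other two measured compounds stand: all three values sit at the limit of > 100000 nM in this assay, at which 3 of the 3 values shown sit, and no difference among them can be read from the half-maximal cytotoxic concentrations shown. Among the measured compounds shown here, no step between measured compounds that differ in a single place is available, so no measured step sets a scale for the change considered here.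

Compound 4 `CS(=O)(=O)c1nn(Cc2nc3cc(Cl)ccc3n2CC2COC2)c2cnccc12` differs from compound 3 by oxetan-3-yl in place of 1-(hydroxymethyl)-1-methylethyl on a saturated chain carbon bound to an aromatic nitrogen. Since every measured value, compound 3 included, sits at the limit of > 100000 nM in this assay, at which 3 of the 3 values shown sit, the expected step in this assay from compound 3 to compound 4 is none beyond the scatter, and a number no higher from compound 3 to compound 4 (the limit leaves the size open) is estimated accordingly. Compound 4 is expected to give 100000 nM, with a range from 50000 nM to 200000 nM, most likely reported once more as a limit rather than as a number.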

Compound 4, half-maximal cytotoxic concentration: > 100000 nM
Compound 4: only a limit was reported; the forecaster's own chance of this, stated with the estimate: 85%; the middle value lies on the limit itself.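

In this assay compound 3 and compound 4 both stand at a limit of the assay and not at a number, so no step can be read between them: the limit of > 100000 nM in this assay, at which 4 of the 4 values shown sit.

The compounds shown leave open whether oxetan-3-yl in place of 1-(hydroxymethyl)-1-methylethyl changes the half-maximal cytotoxic concentration at all, and at what concentration any of the four compounds would reach it.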